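This account rests on a few compounds, and the source may have more. Where it says the series, first, only, none or still open, it means among the compounds named here.

Measured in an ADME assay (liver) for metabolic stability, with Liver microsome (Rattus norvegicus) as the target, using microsomes; a higher number here means faster removal of the compound, a lower number slower removal:
- compound 1 `COc1ccc(-c2nn(-c3nc(C(=O)O)cs3)c3ccccc23)cc1`: 618 mL/min/kg
- compound 2 `O=C(O)c1csc(-n2nc(-c3ccc(C(F)(F)F)cc3)c3ccccc32)n1`: 809 mL/min/kg

Not yet measured: compound 3 `O=C(O)c1csc(-n2nc(N3CCCCC3)c3ccccc32)n1`.

Compound 1 and compound 2 lie within the scatter of each other, so compound 1 has no meaningful rank in this pair. The step to compound 3 is piperidin-1-yl in place of 4-methoxyphenyl on an aromatic carbon. In words, piperidin-1-yl stands in place of 4-methoxyphenyl on an aromatic carbon, two ring bonds from the ring atom that bears a 4-carboxy-1,3-thiazol-2-yl group.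

Among the compounds with values here, only one measured step bears on this change: a 1.3-fold higher number from compound 1 to compound 2 (0.12 log units; within the scatter). That step puts trifluoromethyl in place of methoxy on an aromatic carbon, so the 4-methoxyphenyl group is altered, not replaced. It is therefore only a loose guide. Within the data shown here, no measured compound carries a non-aromatic ring at this place, and the direction of any shift is open. No step beyond the scatter is expected in this assay, though the uncertainty is wide. The estimated step is a 1.1-fold higher number from compound 1 to compound 3 (0.02 log units; within the scatter). Compound 3 is expected at 650 mL/min/kg, with an estimated range of 320 mL/min/kg to 1200 mL/min/kg.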

Compound 3, clearance: 139 mL/min/kg
Compound 3: the middle estimate sits 4.7-fold (0.67 log units) above what was measured; the measured number lies below the stated range.
By their numbers in this assay, from the lowest: compound 3; then compounds 1 and 2 (each within the scatter of the next).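

In this assay, the place on the five-membered aromatic ring with 2 nitrogen proves sensitive once the whole group is exchanged: piperidin-1-yl in place of 4-methoxyphenyl gives a 4.4-fold lower number from compound 1 to compound 3 (0.65 log units; beyond the scatter), whereas the earlier change within the aryl substituent gave only a 1.3-fold higher number from compound 1 to compound 2 (0.12 log units; within the scatter). This single exchange alters several things at once, as a six-membered aromatic ring of carbon only leaves with its methoxy oxygen and a six-membered non-aromatic ring with 1 hetero atom enters, so the step cannot be assigned to any one of these features. No measurement is available that explains the lower number for compound 3.

The compounds shown leave open whether the non-aromatic ring or its ring nitrogen goes with the lower number, a question that a cyclohexyl group at this place would help separate. They also leave open how far the result extends to other amines, such as morpholin-4-yl or an open-chain diethylamino group, and whether it holds with the carboxylic acid replaced by a primary amide.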